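Fluorine placement on the benzyl arm of a triazolyl chalcone

A few compounds are considered here, and "the series" means these few. Any claim that something is new, unique, unknown or untested is made for them only; others in the source may bear on it.

Measured so far:
compound 1 `COc1ccc(C(=O)/C=C/c2ccc(OCc3cn(Cc4ccccc4)nn3)cc2)cc1` — 51%
compound 2 `COc1ccc(C(=O)/C=C/c2ccc(OCc3cn(Cc4ccc(Br)cc4)nn3)cc2)cc1` — 59%
compound 3 `COc1ccc(C(=O)/C=C/c2ccc(OCc3cn(Cc4ccccc4F)nn3)cc2)cc1` — 33%

Of the compounds shown here, three sharing one core have been tested in a functional assay on HepG2 cells (Homo sapiens) for inhibition, read by MTT assay, with a stated time of 48 h, tested at 10 uM; a higher number here means more inhibition of growth at the concentration tested, a lower number less inhibition of growth. Compound 1 `COc1ccc(C(=O)/C=C/c2ccc(OCc3cn(Cc4ccccc4)nn3)cc2)cc1` gives 51% in this assay, compound 2 `COc1ccc(C(=O)/C=C/c2ccc(OCc3cn(Cc4ccc(Br)cc4)nn3)cc2)cc1` gives 59%, and compound 3 `COc1ccc(C(=O)/C=C/c2ccc(OCc3cn(Cc4ccccc4F)nn3)cc2)cc1` gives 33%. Compound 3 stands lowest of the three: its nearest neighbour is compound 1, its furthest compound 2, and both gaps lie beyond the scatter.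

The next compound, compound 4 `COc1ccc(C(=O)/C=C/c2ccc(OCc3cn(Cc4ccc(F)cc4)nn3)cc2)cc1`, differs from compound 3 in one place: 4-fluorophenyl in place of 2-fluorophenyl on a saturated chain carbon bound to an aromatic nitrogen. Among the compounds with values here, two measured steps bear on this. The step from compound 1 to compound 3 is a number 18 percentage points lower from compound 1 to compound 3 (beyond the scatter), and the step from compound 2 to compound 3 is a number 26 percentage points lower from compound 2 to compound 3 (beyond the scatter); the step from compound 1 to compound 2, a number 8 percentage points higher from compound 1 to compound 2 (within the scatter), shows that a bromine in the 4-bromophenyl position left the number within the scatter of the unsubstituted compound 1. Since compound 4 carries its fluorine in the 4-fluorophenyl arrangement, as compound 2 carries its bromine, compound 4 is expected to move back toward compound 1 and compound 2, an upward step of a number 17 percentage points higher from compound 3 to compound 4 (beyond the scatter). Compound 4 is therefore estimated at 50%, with a range from 35% to 65%.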

Compound 4, percent growth inhibition at one concentration: 21%
For compound 4 the middle estimate is 29 percentage points above the measured one; the measured number lies below the stated range.
By their numbers in this assay, from the lowest: compound 4; then compound 3; then compounds 1 and 2 (each within the scatter of the next).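

In this assay, the change from 2-fluorophenyl to 4-fluorophenyl gives a number 12 percentage points lower from compound 3 to compound 4 (beyond the scatter), so the place of the fluorine on the benzyl arm does alter the number, and the 4-fluorobenzyl arrangement does not recover what the 2-fluorobenzyl one lost. The arrangement shared with compound 2 therefore does not carry its result across halogens: fluoro in place of bromo gives a number 38 percentage points lower from compound 2 to compound 4 (beyond the scatter) and fluoro in place of hydrogen gives a number 30 percentage points lower from compound 1 to compound 4 (beyond the scatter), so at this place the identity of the substituent counts, with bromo staying within the scatter of hydrogen while fluoro does not. The data at hand offer nothing that accounts for this difference between the two halogens.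

As far as these compounds go, whether a chloro, a methyl or a methoxy group on the benzyl arm would fall with compound 2 or with compound 4 remains open, as does the effect of an amine or a carboxylic acid at the same place. From the compounds shown here alone, with a single concentration behind each number, it also remains open whether this order would hold across a range of concentrations.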